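Azido in place of hydroxy on the chain

The source may hold more compounds than are shown below. What is called first, only, known or untested is meant among the compounds shown, and "the series" means these compounds.

Measured so far:
compound 1, `CCCCCCCC[C@H](CCO)n1cnc2c(Cl)ncnc21`: 320 nM in a functional assay on SW480 cells (Homo sapiens) for antiproliferative activity, read by MTT assay, with a stated time of 48 h; on this read-out higher numbers stand for weaker inhibition and lower numbers for stronger inhibition
compound 2, `CCCCCCCCC[C@H](CCO)n1cnc2c(Cl)ncnc21`: 1630 nM

Among the compounds with values here, compound 2 holds the highest of the two numbers in this assay; its only neighbour is compound 1, and the one measured step is a 5.1-fold higher number from compound 1 to compound 2 (0.71 log units; beyond the scatter), which concerns a saturated chain carbon nine bonds along the chain from the aromatic nitrogen.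

Compound 3, `CCCCCCCCC[C@H](CCN=[N+]=[N-])n1cnc2c(Cl)ncnc21`, differs from compound 2 by azido in place of hydroxy on a saturated chain carbon, three bonds along the chain from an aromatic nitrogen. Within the data shown here, no measured step touches this place or exchanges hydroxy for another group, so the step from compound 1 to compound 2 gives no guide here, and the direction of the coming step is open. With nothing measured to lean on, the step expected for compound 3 is a 1.0-fold lower number from compound 2 to compound 3 (0.01 log units; within the scatter), kept close to no change. For compound 3 the estimate in this assay is 1600 nM, expected to fall between 400 nM and 6500 nM.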

Compound 3, half-maximal inhibitory concentration: 1220 nM
Compound 3: the middle estimate sits 1.3-fold (0.12 log units) above what was measured, within the range that was stated.
By their numbers in this assay, from the lowest: compound 1; then compounds 3 and 2 (each within the scatter of the next).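

In this assay, the exchange of 2-hydroxyethyl for 2-azidoethyl gives a 1.3-fold lower number from compound 2 to compound 3 (0.13 log units; within the scatter), so this position, unlike the chain carbon changed in the earlier step, shows no change that can be told from the scatter. Azido carries no hydrogen-bond donor where hydroxy carries one, and for this single pair a donor at this place is not required to keep the read-out at the level of the hydroxy compound. No measurement at hand explains why the exchange leaves the number in place.

From the compounds shown here alone, whether azido is tolerated equally on the shorter chain of compound 1 remains open. Also open, going by these compounds, is what an amine or a carboxylic acid at this place would give on either chain.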